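Side-chain swap from compound 2 to compound 3

This account rests on a few compounds, and the source may have more. Where it says the series, first, only, none or still open, it means among the compounds named here.

Of the compounds shown here, two have been read so far, and neither gives a number. In a physicochemical assay for solubility, in phosphate buffer, measured as kinetic solubility, at pH 7.4 (a lower number here means a less soluble compound, a higher number a more soluble compound), compound 1 (`CCCN(CCC)CCNC(=O)C1CCN(Cc2nc(-c3ccccc3C)oc2C)CC1`) gives > 65 ug/mL, which is a limit of the assay. In this assay compound 2 (`Cc1ccccc1-c1nc(CN2CCC(C(=O)N3CCN(C4CCN(C)CC4)CC3)CC2)c(C)o1`) gives > 71 ug/mL, which is also a limit, so its place in the series is known only as a limit.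

Compound 3 (`Cc1ccccc1-c1nc(CN2CCC(C(=O)N3CCN(CCN(C)C)CC3)CC2)c(C)o1`) carries 2-(dimethylamino)ethyl in place of 1-methylpiperidin-4-yl on an amine nitrogen in a ring. Going by the values given here, no measured step exists to size this change in this assay. The expectation therefore rests on compound 2, whose reading of > 71 ug/mL is a limit. The estimated step of an at least 1.0-fold lower number from compound 2 to compound 3 (0.01 log units; that floor lies within the scatter) is expected to stay within the scatter, with no direction favoured, and a further limit is the likely outcome. For compound 3 the expected value is 68 ug/mL, with an estimated range of 45 ug/mL to 90 ug/mL.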

Compound 3, solubility: > 67 ug/mL
Compound 3 ended at the assay's limit (the forecaster's own chance of this, stated with the estimate: 85%); the middle value does not contradict the limit.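

Compound 3 gives a limit in this assay, as do compound 1 and compound 2, so no step among these compounds can be read. The compounds shown leave open whether 2-(dimethylamino)ethyl and 1-methylpiperidin-4-yl give different solubility readings, and how large any difference would be.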